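A few compounds are considered here, and "the series" means these few. Any claim that something is new, unique, unknown or untested is made for them only; others in the source may bear on it.

Within the data shown here, compound 2 `CC(C)C(=O)N1CCC(NC(=O)Nc2ccc(OC(F)(F)F)c(F)c2)CC1` is one of three compounds measured in a physicochemical assay for solubility, read by mass spectrometry, in phosphate buffer, with a stated time of 24 h, at pH 7.4; on this read-out higher numbers stand for higher solubility and lower numbers for lower solubility. There compound 2 gives 5.3 ug/mL. Compound 1 `CC(C)C(=O)N1CCC(NC(=O)Nc2ccc(C(F)(F)F)c(F)c2)CC1` gives 5.9 ug/mL, and the step of a 1.1-fold lower number from compound 1 to compound 2 (0.05 log units; within the scatter) is a change of trifluoromethoxy in place of trifluoromethyl on an aromatic carbon. Compound 3 `CC[C@H](C)C(=O)N1CCC(NC(=O)Nc2ccc(OC(F)(F)F)c(Cl)c2)CC1` gives 0.79 ug/mL, and compound 2 stands second highest of the three numbers, nearest to compound 1 and furthest from compound 3, beyond the scatter.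

Compound 4 `CCC(=O)N1CCC(NC(=O)Nc2ccc(OC(F)(F)F)c(F)c2)CC1` differs from compound 2 by hydrogen in place of methyl on a saturated chain carbon bound to a carbonyl carbon and a saturated chain carbon, that is, isopropylcarbonyl to propanoyl. Among the measured compounds shown here, no measured step bears on this change: the only step recorded, from compound 1 to compound 2, is on an aromatic carbon and stays within the scatter, and compound 3 differs from compound 2 in two places at once, so its lower number cannot be assigned to either. With nothing that speaks to the change on the saturated chain carbon bound to a carbonyl carbon, the expectation for compound 4 is that the number stays close to that of compound 2, with any step a 1.3-fold higher number from compound 2 to compound 4 (0.12 log units; within the scatter) likely within the scatter. Compound 4 is therefore estimated at 7 ug/mL, with a range from 3 ug/mL to 18 ug/mL.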

Compound 4, solubility: 11 ug/mL
Beside the measured number, compound 4's estimate is 1.6-fold (0.20 log units) below it; low and high end bracket the measured number.
By their numbers in this assay, from the lowest: compound 3; then compounds 2, 1 and 4 (each within the scatter of the next, the first and the last beyond it).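

On the saturated chain carbon bound to a carbonyl carbon, the change from isopropylcarbonyl to propanoyl gives in this assay a 2.1-fold higher number from compound 2 to compound 4 (0.32 log units; beyond the scatter), a modest step but the only one shown that lies beyond the scatter. Among these compounds, the earlier compounds could not show this: the one step read among them, on an aromatic carbon, stayed within the scatter, and compound 3 differs from compound 2 in two places at once. This place therefore responds to the loss of a single methyl, although the result rests on one pair of compounds, and nothing available explains the step.

The compounds shown leave open whether the number would keep rising with a still shorter acetyl group, or what a longer chain such as butanoyl, or an amine or a carboxylic acid on that chain, would do. They also leave open whether the same change from isopropylcarbonyl to propanoyl would give a step of similar size in compound 1, which has trifluoromethyl in place of trifluoromethoxy.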